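Propyl Ketone on a Boron Heterocycle: Cytotoxicity Outlook

The compounds below may be only part of what the source reports. "The series", "measured", "known", "first", "only" and "open" are said of these compounds alone.

Compound 1 `OB1OCc2ccc(-n3cc(Sc4ccc(O)cc4)c4ccccc43)cc21`: > 10 ug/mL
Compound 2 `O=C(c1ccc(Cl)cc1)c1ccn(-c2ccc3c(c2)B(O)OC3)c1`: > 10 ug/mL

In an ADME assay on L929 cells (Mus musculus) for cytotoxicity, read by resazurin assay, with a stated time of 72 h (a higher number here means a weaker inhibitor, a lower number a stronger inhibitor), compound 1 reaches only the limit > 10 ug/mL, which is a boundary of the measurement rather than a number. In this assay compound 2 likewise gives only the limit > 10 ug/mL. Among the measured compounds shown here, compound 2 therefore stands where every value so far stands, at the limit of > 10 ug/mL in this assay, at which 2 of the 2 values shown sit, and no measured pair differing in one place exists to set a step. Compound 3 `CCCC(=O)c1ccn(-c2ccc3c(c2)B(O)OC3)c1` is the unmeasured analogue; it differs from compound 2 by propyl in place of 4-chlorophenyl on a carbonyl carbon. For the measured compounds named here, with no measured step to lean on, the expected step from compound 2 to compound 3 in this assay is a step that the limit leaves unreadable from compound 2 to compound 3, that is, none beyond the usual scatter. Compound 3 is accordingly estimated in this assay at 15 ug/mL, with a range of 5 ug/mL to 40 ug/mL, and most likely again only a limit.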

Compound 3, half-maximal inhibitory concentration: > 10 ug/mL
Compound 3: a limit, no number; the forecaster's own chance of this, stated with the estimate: 80%; the middle value does not contradict the limit.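

Compound 2 and compound 3 both give only a limit in this assay, so no step can be read between them: (the limit of > 10 ug/mL in this assay, at which 3 of the 3 values shown sit). The compounds shown leave open whether propyl in place of 4-chlorophenyl on a carbonyl carbon changes the read-out in this assay at all.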